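This account rests on a few compounds, and the source may have more. Where it says the series, first, only, none or still open, it means among the compounds named here.

Measured in a physicochemical assay for solubility; a higher number here means a more soluble compound, a lower number a less soluble compound:
- compound 1 `O=C(Cn1ccnc1)N1CCC(NS(=O)(=O)c2cc(S(=O)(=O)c3ccccc3)ccc2C(F)(F)F)CC1`: 100000 nM
- compound 2 `CC(C)(C)OC(=O)N1CCC[C@@H]1C(=O)N1CCC(NS(=O)(=O)c2cc(S(=O)(=O)c3ccccc3)ccc2C(F)(F)F)CC1`: 25000 nM
- compound 3 `CC(C)(C)OC(=O)N1C(=O)CC[C@H]1C(=O)N1CCC(NS(=O)(=O)c2cc(S(=O)(=O)c3ccccc3)ccc2C(F)(F)F)CC1`: 50000 nM

Compound 2 stands within the scatter of compound 3, while compound 1 has a higher number, beyond the scatter. Next is compound 4 `CC(C)(C)C(=O)N1CCC[C@H]1C(=O)N1CCC(NS(=O)(=O)c2cc(S(=O)(=O)c3ccccc3)ccc2C(F)(F)F)CC1`, reached from compound 2 on a carbonyl carbon: 1-((tert-butyl)carbonyl)pyrrolidin-2-yl in place of 1-(tert-butoxycarbonyl)pyrrolidin-2-yl on a carbonyl carbon. The pyrrolidine ring stays, and 1-((tert-butyl)carbonyl)pyrrolidin-2-yl replaces 1-(tert-butoxycarbonyl)pyrrolidin-2-yl. Among the measured compounds shown here, the one measured step at this place is modest, a 4.0-fold lower number from compound 1 to compound 2 (0.60 log units; beyond the scatter), and it exchanges a different group altogether. For the measured compounds named here, no measured step covers this smaller exchange, so no change beyond the scatter is expected in this assay. The expected step is no change at the digits printed from compound 2 to compound 4 (within the scatter). Compound 4 is estimated at 25000 nM, with an expected range of 10000 nM to 60000 nM.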

Compound 4, solubility: 50000 nM
The estimate for compound 4 lay 2.0-fold (0.30 log units) below the measured number; the measured number falls inside the stated range.
By their numbers in this assay, from the lowest: compounds 2, 3, 4 and 1 (each within the scatter of the next, the first and the last beyond it).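

In this assay, 1-((tert-butyl)carbonyl)pyrrolidin-2-yl in place of 1-(tert-butoxycarbonyl)pyrrolidin-2-yl on a carbonyl carbon gives a 2.0-fold higher number from compound 2 to compound 4 (0.30 log units; within the scatter), so this smaller exchange stays inside the scatter. The same entering group in place of (1H-imidazol-1-yl)methyl gives a 2.0-fold lower number from compound 1 to compound 4 (0.30 log units; within the scatter), whereas the exchange to the tert-butoxycarbonyl group gives a 4.0-fold lower number from compound 1 to compound 2 (0.60 log units; beyond the scatter), so a gap to compound 1 beyond the scatter is not common to both pyrrolidine compounds. No measurement available here bears on a reason for this. Open, as far as these compounds go, is whether a free pyrrolidine amine, or a carboxylic acid in place of the tert-butyl group, would give a step beyond the scatter.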